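Swapping bromo for chloro on the 3-bromophenyl group

The source may report more compounds than this note shows. Statements on the series, on what has been measured and on what is new or still open speak of the compounds shown alone.

Measured in a functional assay on DU-145 cells (Homo sapiens) for antiproliferative activity, read by sulforhodamine B assay, with a stated time of 48 h; a lower number here means a stronger inhibitor, a higher number a weaker inhibitor:
- Compound 1 `COc1cc(NS(=O)(=O)c2ccc(N3CCNC3=O)cc2)cc(OC)c1OC`: 51 nM
- Compound 2 `O=C1NCCN1c1ccc(S(=O)(=O)Nc2cccc(Br)c2)cc1`: 340 nM

Only these two compounds have been measured, and they differ in more than one place. Compound 2 has the higher number of the pair at 340 nM, so it is the weaker inhibitor, and its gap to compound 1 at 51 nM lies beyond the scatter.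

Compound 3 `O=C1NCCN1c1ccc(S(=O)(=O)Nc2cccc(Cl)c2)cc1` keeps the structure of compound 2, with chloro in place of bromo on an aromatic carbon. In other words, 3-bromophenyl becomes 3-chlorophenyl. Within the data shown here, no measured pair shows this swap, so the expectation is a judgement rather than a read-across. For such a small exchange, no step beyond the scatter is expected in this assay.

The expected result is a 1.2-fold higher number from compound 2 to compound 3 (0.07 log units; within the scatter).

Compound 3 is estimated at 400 nM, with an expected range of 160 nM to 1000 nM.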

Compound 3, half-maximal inhibitory concentration: 230 nM
Estimate against measurement, compound 3: 1.7-fold (0.24 log units) above, and the stated range covers the measured number.
By their numbers in this assay, from the lowest: compound 1; then compounds 3 and 2 (each within the scatter of the next).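

In this assay, among these compounds, this pair gives the first direct comparison at this place on the aromatic ring, with only the halogen exchanged: chloro in place of bromo gives a 1.5-fold lower number from compound 2 to compound 3 (0.17 log units; within the scatter) and leaves everything else in the molecule untouched. At this place, then, the assay cannot tell 3-bromophenyl and 3-chlorophenyl apart, so this exchange can be treated as neutral for now, on the strength of a single pair. No supporting measurement is available to explain why the two compounds read alike.

As far as these compounds go, whether the position tolerates only these two halogens remains open, since a fluoro or iodo group could extend the comparison within the same family. An amine or a carboxylic acid at this place would test a quite different kind of group on the same ring.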